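This account rests on a few compounds, and the source may have more. Where it says the series, first, only, none or still open, it means among the compounds named here.

Compound 1, `C=Cn1c2ccc([N+](=O)[O-])cc2c(=O)n1Cc1ccccc1`, gives 160000 nM in an ADME assay on L929 cells (Mus musculus) for cytotoxicity, read by resazurin assay, with a stated time of 48 h; on this read-out higher numbers stand for lower toxicity in this test and lower numbers for higher toxicity in this test.
Compound 2, `C#CCn1c2ccc([N+](=O)[O-])cc2c(=O)n1Cc1ccccc1`, gives 195000 nM.
Compound 3, `O=c1c2cc([N+](=O)[O-])ccc2n(CCCBr)n1Cc1ccccc1`, gives 25200 nM.

Among these three, compound 3 stands lowest, which on this read-out means the highest toxicity in this test. Its nearest neighbour is compound 1, with the gap a 6.3-fold lower number from compound 1 to compound 3 (0.80 log units; beyond the scatter), and the furthest is compound 2, with the gap a 7.7-fold lower number from compound 2 to compound 3 (0.89 log units; beyond the scatter). Compound 1 and compound 2 lie within the scatter of each other, as a 1.2-fold higher number from compound 1 to compound 2 (0.09 log units; within the scatter) shows.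

The next compound, compound 4, is `O=c1c2cc([N+](=O)[O-])ccc2n(CCO)n1Cc1ccccc1`. It differs from compound 3 in one place: hydroxy in place of bromomethyl on a saturated chain carbon, two bonds along the chain from an aromatic nitrogen. For the measured compounds named here, no measured step introduces a hydroxy group, so the only guidance comes from the two steps that brought 3-bromopropyl or 2-bromoethyl into compound 3, namely a 6.3-fold lower number from compound 1 to compound 3 (0.80 log units; beyond the scatter) and a 7.7-fold lower number from compound 2 to compound 3 (0.89 log units; beyond the scatter), both modest and both toward a lower number. On these data alone, removing bromomethyl is therefore expected to move the number part of the way back toward compound 1 and compound 2, though how far the hydroxy group itself shifts it is unknown. Compound 4 is expected at 100000 nM, between 40000 nM and 250000 nM, a step of a 4.0-fold higher number from compound 3 to compound 4 (0.60 log units; beyond the scatter).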

Compound 4, concentration lethal to 50% of the cells: > 256000 nM
Compound 4: no number, only a limit; the forecaster's own chance of this, stated with the estimate: 15%; middle value at least 2.5-fold (0.40 log units) away from the limit.
By their numbers in this assay, from the lowest: compound 3; then compounds 1 and 2 (each within the scatter of the next). At a limit, above all of these: compound 4.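

Hydroxy in place of bromomethyl is the first change shown that moves the number clearly upward from compound 3 in this assay, with an at least 10-fold higher number from compound 3 to compound 4 (1.00 log units; beyond the scatter), so the low number of compound 3 goes with its 3-bromopropyl chain and does not carry over to the shared core as such. The comparisons with the vinyl and propargyl chains give only floors, an at least 1.6-fold higher number from compound 1 to compound 4 (0.20 log units; that floor lies within the scatter) and an at least 1.3-fold higher number from compound 2 to compound 4 (0.11 log units; that floor lies within the scatter), so neither can be read as a real difference. Compound 4 has no true number, only a limit of the assay, so the real size of all these steps stays unknown: the limit of > 256000 nM in this assay, at which 1 of the 4 values shown sits.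

The compounds shown do not tell whether the lower number of compound 3 follows the bromine atom or the length of the chain, and a plain propyl chain or a 3-chloropropyl chain would speak to that. Nor do they show how the hydroxy end compares with an amine or a carboxylic acid at the end of the same chain.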